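The source may hold more compounds than are shown below. What is called first, only, known or untested is meant among the compounds shown, and "the series" means these compounds.

Within the data shown here, compound 1 `COc1cc2c(cc1OC)CN(S(=O)(=O)c1ccc(-n3cc(COc4ccc5ccccc5c4)nn3)cc1)CC2` and compound 2 `COc1cc2c(cc1OC)CN(S(=O)(=O)c1ccc(-n3cc(COc4ccccc4)nn3)cc1)CC2` are the only compounds measured in an ADME assay on Vero cells (Chlorocebus sabaeus) for cytotoxicity, with a stated time of 4 days; a higher number here means a weaker inhibitor, a lower number a stronger inhibitor. In this assay compound 1 gives > 50 ug/mL, a limit of the assay. In this assay compound 2 gives > 50 ug/mL, likewise a limit. The step that the two limits leave unreadable from compound 1 to compound 2 is therefore not readable, and compound 2 stands at the limit of > 50 ug/mL in this assay, at which 2 of the 2 values shown sit. Compound 3 `COc1cc2c(cc1OC)CN(S(=O)(=O)c1ccc(-n3cc(COc4ccc(C=O)cc4OC)nn3)cc1)CC2` differs from compound 2 by 4-formyl-2-methoxyphenyl in place of phenyl on an oxygen on a saturated carbon. Among the measured compounds shown here, no measured step supplies a readable size for this kind of change, so no shift beyond the scatter is expected. The step that the limit leaves unreadable from compound 2 to compound 3 is expected to be none. Compound 3 is estimated at 60 ug/mL, within 35 ug/mL to 200 ug/mL.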

Compound 3, half-maximal inhibitory concentration: > 50 ug/mL
Compound 3 ended at the assay's limit; the forecaster's own chance of this, stated with the estimate: 80%; the middle value does not contradict the limit.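

No new step can be read from compound 1 or compound 2 to compound 3; all three stand at one limit: the limit of > 50 ug/mL in this assay, at which 3 of the 3 values shown sit.

In this assay the compounds shown leave open how far past that limit each lies, and whether changing the group on the oxygen shifts the value at all.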